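From a furan ring to a pyrazole ring: what to expect

The source may report more compounds than this note shows. Statements on the series, on what has been measured and on what is new or still open speak of the compounds shown alone.

Of the compounds shown here, three have been measured in an in vitro functional assay on HEK285-7 cells for antagonist activity at prostaglandin D2 receptor 2 (Homo sapiens), read by BRET and beta-arrestin recruitment; a lower number here means a stronger inhibitor, a higher number a weaker inhibitor. Compound 1 `N#Cc1cc(-c2nc(C(c3ccc(F)cc3)c3ccc(F)cc3)sc2CC(=O)O)ccc1F` gives 520 nM. Compound 2 `O=C(O)Cc1sc(C(c2ccc(F)cc2)c2ccc(F)cc2)nc1-c1ccoc1` gives 130 nM, and compound 3 `O=C(O)Cc1sc(C(c2ccccc2)c2ccc(Cl)cc2)nc1-c1ccc(Cl)cc1` gives 75 nM. Among these three numbers compound 2 stands second highest; compound 3 is its nearest neighbour and lies within the usual scatter of it, while compound 1 lies furthest away, beyond the scatter. Going by the values given here, the only step measured between compounds that differ in a single place is a 4.0-fold lower number from compound 1 to compound 2 (0.60 log units; beyond the scatter), in which furan-3-yl replaces 3-cyano-4-fluorophenyl on an aromatic carbon.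

The unmeasured compound 4 `O=C(O)Cc1sc(C(c2ccc(F)cc2)c2ccc(F)cc2)nc1-c1cn[nH]c1` differs from compound 2 in one place: 1H-pyrazol-4-yl in place of furan-3-yl on an aromatic carbon. Both the leaving group and the entering group are one five-membered aromatic ring, though the entering ring brings a hydrogen-bond donor that the leaving ring lacks. Among the compounds with values here, no measured step speaks directly to this exchange. Within the data shown here, the step from compound 1 to compound 2 shows only that a five-membered ring at this position gave a lower number than a substituted phenyl ring; it says nothing about one five-membered ring against another. The expected step is therefore no change at the digits printed from compound 2 to compound 4 (within the scatter), which is within the scatter. Compound 4 is estimated at 130 nM, with a range from 45 nM to 380 nM.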

Compound 4, half-maximal inhibitory concentration: 220 nM
For compound 4 the middle estimate is 1.7-fold (0.23 log units) below the measured one; low and high end bracket the measured number.
By their numbers in this assay, from the lowest: compounds 3, 2 and 4 (each within the scatter of the next, the first and the last beyond it); then compound 1.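

In this assay, the step from furan-3-yl to 1H-pyrazol-4-yl is a 1.7-fold higher number from compound 2 to compound 4 (0.23 log units; within the scatter), so compound 2 and compound 4 cannot be told apart, even though the entering ring has two hetero atoms and a hydrogen-bond donor where the leaving ring has one hetero atom and no donor. The comparison with the substituted phenyl ring is a 2.4-fold lower number from compound 1 to compound 4 (0.37 log units; beyond the scatter), which means that compound 1 is now set apart from two different five-membered rings at this position, not from the furan alone, and the earlier gap was therefore not unique to the furan-3-yl group. No measurement available here gives a reason for either step.

Going by these compounds, it remains open whether a 1-methyl-1H-pyrazol-4-yl group, which keeps the pyrazole ring but replaces the hydrogen on its nitrogen with a methyl group, would read the same as the 1H-pyrazol-4-yl group in compound 4. An unsubstituted phenyl ring at the same place would show whether the gap from compound 1 belongs to the six-membered ring itself or to its nitrile and fluorine.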